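Trimming a fused ring: compound 3 from compound 2

The compounds below may be only part of what the source reports. "The series", "measured", "known", "first", "only" and "open" are said of these compounds alone.

Compound 2 `COc1ncnc2c1c(-c1cc3ccccc3o1)cn2[C@@H]1O[C@H](CO)[C@@H](O)[C@H]1O` gives the lowest of the two numbers seen so far in an ADME assay on BJ cells (Homo sapiens), read by MTT assay, with a stated time of 72 h (a higher number here means a weaker inhibitor, a lower number a stronger inhibitor), at 22400 nM. Among the compounds with values here, compound 1 `COc1ncnc2c1c(-c1cccs1)cn2[C@@H]1O[C@H](CO)[C@@H](O)[C@H]1O`, which shares the same core, gives 62800 nM in this assay, and the only measured step, a 2.8-fold lower number from compound 1 to compound 2 (0.45 log units; beyond the scatter), put 1-benzofuran-2-yl in place of thiophen-2-yl on an aromatic carbon.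

Compound 3 `COc1ncnc2c1c(-c1ccco1)cn2[C@@H]1O[C@H](CO)[C@@H](O)[C@H]1O` differs from compound 2 in one place: furan-2-yl in place of 1-benzofuran-2-yl on an aromatic carbon. This change undoes part of what the measured step introduced, replacing the two-ring group with a single five-membered ring, as compound 1 also carries. Since that step from compound 1 to compound 2 gave a modest lower number, returning to a one-ring group is expected to move the number back up by a similar, modest amount, a 2.2-fold higher number from compound 2 to compound 3 (0.35 log units; beyond the scatter). Compound 3 is therefore estimated to give 50000 nM in this assay, with a likely range from 20000 nM to 130000 nM.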

Compound 3, half-maximal inhibitory concentration: 430 nM
The estimate for compound 3 lay 120-fold (2.07 log units) above the measured number; the whole stated range lies above it.
By their numbers in this assay, from the lowest: compound 3; then compound 2; then compound 1.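

In this assay, the group on this aromatic carbon of the shared core matters far more than the first step suggested: furan-2-yl in compound 3 gives a much lower number than either the two-ring group (a 52-fold lower number from compound 2 to compound 3 (1.72 log units; beyond the scatter)) or thiophen-2-yl (a 150-fold lower number from compound 1 to compound 3 (2.16 log units; beyond the scatter)). The number of rings alone does not order these compounds, since the single-ring furan-2-yl gives the lowest number, while the single-ring thiophen-2-yl gives the highest and the two-ring 1-benzofuran-2-yl lies in the middle. Nothing available explains why swapping one five-membered ring for another shifts the number so sharply.

The three compounds leave open whether this low number is specific to furan-2-yl or would also appear with a pyrrol-2-yl or phenyl ring at this position. They also do not show what a non-aromatic group, such as an amine or a short alkyl chain, would do here.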